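Chloro to Fluoro: Expected Cytotoxicity of Compound 3

The source may hold more compounds than are shown below. What is called first, only, known or untested is meant among the compounds shown, and "the series" means these compounds.

Compound 1, `O=C(Nc1ccc(N=C2NCCN2)cc1)c1ccc(N=C2NCCN2)cc1F`, in an ADME assay on HEK-293T cells (Homo sapiens) for cytotoxicity, read by resazurin assay, with a stated time of 30 h (on this read-out higher numbers stand for lower toxicity in this test and lower numbers for higher toxicity in this test), gives > 200000 nM, which is a limit of the assay and not a number.
Compound 2, `O=C(Nc1ccc(N=C2NCCN2)c(Cl)c1)c1ccc(N=C2NCCN2)cc1`, in this assay gives > 200000 nM, again a limit rather than a number.

Among the compounds with values here, compound 2 therefore sits at the same limit as the only other value shown, (the limit of > 200000 nM in this assay, at which 2 of the 2 values shown sit). Compound 3, `O=C(Nc1ccc(N=C2NCCN2)c(F)c1)c1ccc(N=C2NCCN2)cc1`, differs from compound 2 by fluoro in place of chloro on an aromatic carbon. Within the data shown here, no measured step links two compounds here, so no change beyond the scatter is expected in this assay. Compound 3 is expected to give 200000 nM (range 100000 nM to 400000 nM), most likely reported again as a limit, an estimated step of a number no higher from compound 2 to compound 3 (the limit leaves the size open).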

Compound 3, half-maximal cytotoxic concentration: > 200000 nM
Compound 3 gave a limit, no number; the forecaster's own chance of this, stated with the estimate: 85%; the middle value sits exactly at the limit.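

Within the data shown here, compound 2 and compound 3 both stop at a limit and not a number, so no step from chloro to fluoro can be read between them: the limit of > 200000 nM in this assay, at which 3 of the 3 values shown sit.
On these data alone, what this assay would show for these compounds past that limit, and so whether fluoro in place of chloro changes anything, stays open.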